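The source may report more compounds than this note shows. Statements on the series, on what has been measured and on what is new or still open speak of the compounds shown alone.

Series notes. In an assay on isolated protein for displacement of a labelled ligand from metabotropic glutamate receptor 5 (Homo sapiens), with a stated time of 60 min, tested at 1 uM (on this read-out lower numbers stand for less inhibition and higher numbers for more inhibition at the one concentration tested (going by the name of the read-out)), compound 1 `CCN1CCN(c2c(S(=O)(=O)c3ccccc3)cnc3ccccc23)CC1` gives 1.7%, the lowest of the three numbers in hand. Compound 2 `O=S(=O)(c1ccccc1)c1cnc2ccccc2c1N1CCCCCC1` gives 79.9% and compound 3 `NC(=O)C1CCN(c2c(S(=O)(=O)c3ccccc3)cnc3ccccc23)CC1` gives 24.8%; the steps run a number 78.2 percentage points higher from compound 1 to compound 2 (beyond the scatter) and a number 23.1 percentage points higher from compound 1 to compound 3 (beyond the scatter), while a number 55.1 percentage points lower from compound 2 to compound 3 (beyond the scatter). The unmeasured compound 4 `O=S(=O)(c1ccccc1)c1cnc2ccccc2c1N1CCN(c2ccccc2)CC1` differs from compound 1 by phenyl in place of ethyl on an amine nitrogen in a ring. Among the measured compounds shown here, no measured step alters the group on this ring nitrogen; both known steps from compound 1 swap out the whole ring and each raises inhibition beyond the scatter, so a rise of uncertain size is also expected for compound 4, a number 33.3 percentage points higher from compound 1 to compound 4 (beyond the scatter). Compound 4 is therefore estimated at 35%, with a range from 5% to 75%.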

Compound 4, a percentage reported as inhibition, at one concentration (the size of the read-out at that concentration, not a potency): 13.5%
Compound 4: middle estimate off by 21.5 percentage points, on the high side, and the stated range covers the measured number.
By their numbers in this assay, from the lowest: compound 1; then compound 4; then compound 3; then compound 2.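

With the piperazine-type ring kept and only the group on its ring nitrogen changed, a number 11.8 percentage points higher from compound 1 to compound 4 (beyond the scatter) in this assay, so this nitrogen does respond to substitution, which the earlier whole-ring swaps could not show. The step is modest, and much smaller than the one printed for the ring swap, a number 78.2 percentage points higher from compound 1 to compound 2 (beyond the scatter), so phenyl on this nitrogen recovers little of what azepan-1-yl gives. Nothing available explains the rise from ethyl to phenyl. Still open, on these data alone, is whether a benzyl group, an acetyl group or a bare amine hydrogen on this nitrogen would move the number further, and whether a substituted phenyl would do so.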